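Nitrooxy for bromo on a chalcone amide chain

The source may hold more compounds than are shown below. What is called first, only, known or untested is meant among the compounds shown, and "the series" means these compounds.

Measured compounds:
Compound 1 `O=C(CBr)Nc1ccc(C(=O)/C=C/c2ccco2)cc1`: 25%
Compound 2 `O=C(CO[N+](=O)[O-])Nc1ccc(C(=O)/C=C/c2ccco2)cc1`: 39%
Compound 3 `CC(Br)C(=O)Nc1ccc(C(=O)/C=C/c2ccc(Cl)cc2)cc1`: 50%

The three measured compounds were tested in a functional assay on the whole organism (strain albino) for inhibition, with Rattus norvegicus as the target, read by paw edema, with stated times of 30 min and 5 h, at a dose of 100 mg/kg by the oral route; on this read-out higher numbers stand for more inhibition at the one dose given (going by the name of the read-out) and lower numbers for less inhibition. Compound 1 gives 25%, compound 2 gives 39%, and compound 3 gives 50%, the highest of the three, with its steps to both others beyond the scatter.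

Compound 2 differs from compound 1 by nitrooxy in place of bromo on a saturated chain carbon bound to a carbonyl carbon, and this change made a number 14 percentage points higher from compound 1 to compound 2 (beyond the scatter). Compound 4 `CC(O[N+](=O)[O-])C(=O)Nc1ccc(C(=O)/C=C/c2ccc(Cl)cc2)cc1` has not yet been measured; it differs from compound 3 by nitrooxy in place of bromo on a saturated chain carbon bound to a carbonyl carbon and a saturated chain carbon. The difference between the core of compound 1 and the core of compound 3 is not broken down here. The surroundings of the place also differ: in compound 4 the saturated chain carbon is bound to a carbonyl carbon and a saturated chain carbon, whereas in compound 2 it is bound to a carbonyl carbon only, so this is the same kind of change rather than the same change.

Going by the values given here, the step from compound 3 to compound 4 is expected to be a number 12 percentage points higher from compound 3 to compound 4 (beyond the scatter), resting on the one precedent, in which compound 2 showed a number 14 percentage points higher from compound 1 to compound 2 (beyond the scatter). Compound 4 is therefore estimated at 62%, between 48% and 76%.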

Compound 4, a percentage reported as inhibition, in the whole organism at one dose (the size of the read-out at that dose, not a potency): 56%
For compound 4 the middle estimate is 6 percentage points above the measured one; low and high end bracket the measured number.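

In this assay, nitrooxy in place of bromo gives a number 6 percentage points higher from compound 3 to compound 4 (within the scatter), so on the core of compound 3 the change cannot be told apart from no change at all. Set beside the earlier step, this result does not show that the two cores respond differently: the same change on two cores in this assay, a number 14 percentage points higher (beyond the scatter) from compound 1 to compound 2 and a number 6 percentage points higher (within the scatter) from compound 3 to compound 4, 8 percentage points apart, within the scatter of two such steps. Going by these compounds alone, the two steps are therefore compatible with a change that carries over from one core to the other, but they do not establish this, since they rest on only two pairs, only one of the steps lies beyond the scatter, and the chain carbon carrying the group has different surroundings in the two pairs.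

The compounds shown leave open how the same change behaves on further cores, and whether it would hold on a longer chain. They also leave open how a hydroxyl group or an amine on the same chain carbon, in place of bromo or nitrooxy, would read in this assay.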